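Compound 3 to compound 4: methylsulfonyl on the amine nitrogen

The source may report more compounds than this note shows. Statements on the series, on what has been measured and on what is new or still open speak of the compounds shown alone.

compound 1 (`COc1ccc(-c2c(C)nc3c(N4CC[C@@H](NC(C)=O)C4)cc(C)nn23)cc1OC`) gives > 95% as a limit
compound 2 (`COc1ccc(-c2c(C)nc3c(N4CC[C@@H](NC(=O)c5ccccc5)C4)cc(C)nn23)cc1OC`) gives > 95% as a limit
compound 3 (`COc1ccc(-c2c(C)nc3c(N4CC[C@@H](NC(=O)OC5CCCCC5)C4)cc(C)nn23)cc1OC`) gives > 95% as a limit

In an ADME assay on microsomes from liver (Mus musculus) for metabolic stability, read by LC-MS, with NADPH named in the record, with a stated time of 60 min, tested at 1 uM, in the absence of a further agent (on this read-out higher numbers stand for a more stable compound and lower numbers for a less stable compound), compound 3 gives > 95% as a limit of the assay and not a number. The evidence is the limit of > 95% in this assay, at which 3 of the 3 values shown sit, and no order among the three compounds can be read from it.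

Compound 4 (`COc1ccc(-c2c(C)nc3c(N4CC[C@@H](NS(C)(=O)=O)C4)cc(C)nn23)cc1OC`) carries methylsulfonyl in place of cyclohexyloxycarbonyl on an amine nitrogen.

Bearing on this are a step that the two limits leave unreadable from compound 1 to compound 2 together with a step that the two limits leave unreadable from compound 1 to compound 3 and a step that the two limits leave unreadable from compound 2 to compound 3 as the third. None of these has a readable size, and none brings in methylsulfonyl. Compound 3 holds > 95% as its limit, and from that no step beyond the scatter is expected in this assay here. The step expected is a number no higher from compound 3 to compound 4 (the limit leaves the size open) by this estimate. Compound 4 is estimated at 95% with an expected range of 85% to 100% for the measurement.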

Compound 4, percent of the compound remaining: > 95%
Compound 4 was reported as a limit; the forecaster's own chance of this, stated with the estimate: 70%; the middle value sits exactly at the limit.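

In this assay compound 4 gives > 95%, a limit of the assay and not a number. Its steps from compound 1, compound 2 and compound 3 cannot be read: the limit of > 95% in this assay, at which 4 of the 4 values shown sit.

Going by these compounds, the order of stability among compound 1, compound 2, compound 3 and compound 4 stays open, as does any effect of the group on the amine nitrogen.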